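The source may report more compounds than this note shows. Statements on the series, on what has been measured and on what is new or still open speak of the compounds shown alone.

Compound 3 `CCc1ccc(N2C(=O)NC3(CSC4=C3C(=O)c3ncccc3C4=O)C2=O)cc1` carries the shared core of this series with a 4-ethylphenyl group on an amide-type nitrogen in a ring. In a functional assay on CCRF-CEM cells (Homo sapiens) for antiproliferative activity, read by MTT assay, with a stated time of 96 h (a higher number here means a weaker inhibitor, a lower number a stronger inhibitor), compound 3 gives 10 nM, the second highest of the three numbers measured. Compound 1 `CN(C)c1ccc(N2C(=O)NC3(CSC4=C3C(=O)c3ncccc3C4=O)C2=O)cc1`, which bears 4-(dimethylamino)phenyl at that nitrogen, gives 1 nM in this assay, while compound 2 `O=C1NC(=O)C2(CSC3=C2C(=O)c2ncccc2C3=O)N1`, with only hydrogen there, gives 120 nM. Two steps are large: a 120-fold higher number from compound 1 to compound 2 (2.08 log units; beyond the scatter), and a 12-fold lower number from compound 2 to compound 3 (1.08 log units; beyond the scatter). Within the data shown here, the step of a 10-fold higher number from compound 1 to compound 3 (1.00 log units; beyond the scatter) bears most on what follows, since it is the only change at the aromatic carbon of the six-membered aromatic ring of carbon only.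

Compound 4 `CC(C)(C)c1ccc(N2C(=O)NC3(CSC4=C3C(=O)c3ncccc3C4=O)C2=O)cc1` differs from compound 3 by tert-butyl in place of ethyl on an aromatic carbon. Among the measured compounds shown here, nothing measured here tells how tert-butyl fares against ethyl; the one comparison at this aromatic carbon, compound 1 against compound 3, shows that exchanging the group there shifts the number by a modest amount. Compound 4 is expected to stay close to compound 3, with a step of no change at the digits printed from compound 3 to compound 4 (within the scatter) that does not go beyond the scatter. The estimate for compound 4 in this assay is 10 nM, within a range from 3 nM to 40 nM.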

Compound 4, half-maximal inhibitory concentration: 200 nM
The estimate for compound 4 lay 20-fold (1.30 log units) below the measured number; measured number outside the range, above it.
By their numbers in this assay, from the lowest: compound 1; then compound 3; then compounds 2 and 4 (each within the scatter of the next).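

In this assay the exchange of ethyl for tert-butyl, with 2 heavy carbon atoms leaving, 4 entering and no hydrogen-bond donor, acceptor or net charge on either side, gives a 20-fold higher number from compound 3 to compound 4 (1.30 log units; beyond the scatter) and so shows that a change between plain carbon groups at this aromatic carbon can be a large one. With a 1.7-fold higher number from compound 2 to compound 4 (0.22 log units; within the scatter) as the step from the bare nitrogen, the 4-(tert-butyl)phenyl group keeps compound 4 within the scatter of compound 2, so an aryl group on the amide-type nitrogen does not by itself bring the low numbers of compound 1 and compound 3. The span at this aromatic carbon now reaches a 200-fold higher number from compound 1 to compound 4 (2.30 log units; beyond the scatter) and nothing given here accounts for it.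

The compounds shown leave open how methyl, isopropyl or a longer chain such as n-propyl would fare at this aromatic carbon, and so whether the step follows the count of carbons or belongs to tert-butyl alone. They also leave open whether another amine, such as methylamino or pyrrolidine, or a methoxy group would stay as close to compound 1 as its dimethylamino group.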